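A few compounds are considered here, and "the series" means these few. Any claim that something is new, unique, unknown or untested is made for them only; others in the source may bear on it.

Measured compounds in a functional assay on FM3A cells (Mus musculus) for antiproliferative activity; on this read-out higher numbers stand for weaker inhibition and lower numbers for stronger inhibition:
- compound 1, `COc1cc(C(=O)c2sc(-c3ccc(Br)cc3)cc2N)cc(OC)c1OC`: 150 nM
- compound 2, `COc1cc(C(=O)c2sc(-c3cccc([N+](=O)[O-])c3)cc2N)cc(OC)c1OC`: 17 nM
- compound 3, `COc1cc(C(=O)c2sc(-c3ccc(Cl)c(Cl)c3)cc2N)cc(OC)c1OC`: 400 nM

All three compounds share a core and differ only in the aromatic group attached to it. On the numbers shown, compound 1 holds the middle place: compound 3 lies above it and compound 2 below it, with a 2.7-fold higher number from compound 1 to compound 3 (0.43 log units; beyond the scatter) and an 8.8-fold lower number from compound 1 to compound 2 (0.95 log units; beyond the scatter) both beyond the scatter, so the aromatic group clearly matters here.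

Compound 4, `COc1cc(C(=O)c2sc(-c3cccs3)cc2N)cc(OC)c1OC`, has not yet been measured. It differs from compound 1 in one place: thiophen-2-yl in place of 4-bromophenyl on an aromatic carbon

Both measured steps that change this same group bear on the question. Swapping the group gave a modest drop with an 8.8-fold lower number from compound 1 to compound 2 (0.95 log units; beyond the scatter) and a modest rise with a 2.7-fold higher number from compound 1 to compound 3 (0.43 log units; beyond the scatter). Neither step introduces a five-membered ring, so none tells what a thiophen-2-yl group does. With no closer guide, the step of a 1.3-fold higher number from compound 1 to compound 4 (0.12 log units; within the scatter) is expected to stay near or slightly above compound 1, within the range the group swaps have shown. Compound 4 is therefore estimated at 200 nM, between 60 nM and 700 nM.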

Compound 4, half-maximal inhibitory concentration: 1.7 nM
For compound 4 the middle estimate is 120-fold (2.07 log units) above the measured one, and the stated range ends above it.
By their numbers in this assay, from the lowest: compound 4; then compound 2; then compound 1; then compound 3.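

In this assay, thiophen-2-yl gives the lowest number of the four compounds, with steps to it from each phenyl compound: (an 88-fold lower number from compound 1 to compound 4 (1.95 log units; beyond the scatter)), (a 240-fold lower number from compound 3 to compound 4 (2.37 log units; beyond the scatter)) and (a 10-fold lower number from compound 2 to compound 4 (1.00 log units; beyond the scatter)). This position is therefore not limited to six-membered rings of carbon, and a five-membered aromatic ring with 1 hetero atom gives stronger inhibition than any of the three phenyl groups shown. Nothing measured here explains this gain.

With only one five-membered ring among the compounds shown, it remains open whether the result depends on the ring sulfur, on the ring size or on the point of attachment. A furan-2-yl, a thiophen-3-yl and a plain phenyl group would help separate these possibilities.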